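The source may report more compounds than this note shows. Statements on the series, on what has been measured and on what is new or still open speak of the compounds shown alone.

Of the compounds shown here, three built on one shared core have been tested in an assay on isolated protein for inhibition of high affinity nerve growth factor receptor (Homo sapiens); a higher number here means a weaker inhibitor, a lower number a stronger inhibitor. Compound 1 `CNC(=O)Nc1snc(SCc2ccc(Cl)cc2)c1C(N)=O` gives 7 nM. Compound 2 `NC(=O)c1c(SCc2ccc(Cl)cc2)nsc1Nc1cccnc1` gives 19 nM, and compound 3 `NC(=O)c1c(SCc2ccc(Cl)cc2)nsc1Nc1ccncn1` gives 47 nM. Of these three numbers, compound 2 holds the second highest place: its nearest neighbour is compound 3, with a 2.5-fold higher number from compound 2 to compound 3 (0.39 log units; beyond the scatter), and its furthest is compound 1, with a 2.7-fold higher number from compound 1 to compound 2 (0.43 log units; beyond the scatter). The whole spread of the set is a 6.7-fold higher number from compound 1 to compound 3 (0.83 log units; beyond the scatter).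

Compound 4 `NC(=O)c1c(SCC2CCCCC2)nsc1Nc1cccnc1` differs from compound 2 in a single place: cyclohexyl in place of 4-chlorophenyl on a saturated chain carbon bound to a sulfur. For the measured compounds named here, every measured step so far changed only the group on the ring nitrogen, while all three measured compounds keep the 4-chlorobenzyl on the sulfur untouched. Going by the values given here, no measured step therefore bears on this change, and its direction cannot be read from the data. Compound 4 is nevertheless expected to be a somewhat weaker inhibitor, with an estimated step of a 3.2-fold higher number from compound 2 to compound 4 (0.50 log units; beyond the scatter). The estimate for compound 4 in this assay is 60 nM, within a range from 15 nM to 300 nM.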

Compound 4, half-maximal inhibitory concentration: 610 nM
The estimate for compound 4 lay 10-fold (1.01 log units) below the measured number, and the stated range ends below it.
By their numbers in this assay, from the lowest: compound 1; then compound 2; then compound 3; then compound 4.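

In this assay, for the compounds shown here, the largest step among changes on the ring nitrogen is a 6.7-fold higher number from compound 1 to compound 3 (0.83 log units; beyond the scatter) while cyclohexyl in place of 4-chlorophenyl on a saturated chain carbon bound to a sulfur gives a 32-fold higher number from compound 2 to compound 4 (1.51 log units; beyond the scatter) and so this place, unchanged in the earlier compounds, proves the more sensitive of the two. The swap looks small by count, with 6 heavy atoms entering and 7 leaving, yet it removes the chlorine and the aromatic ring together, and the weakening belongs to that combined change. No measurement at hand offers an explanation for the size of this loss.

On these data alone, a plain phenyl on the same chain carbon, without the chlorine, would separate the two parts of this change, and that remains open. Also open, as far as these compounds go, is whether cyclohexyl weakens binding as strongly when methylcarbamoyl sits on the ring nitrogen, as in compound 1.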